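Flipping One Stereocentre in a Compound with a Low Number in a Methyltransferase Assay

The source may report more compounds than this note shows. Statements on the series, on what has been measured and on what is new or still open speak of the compounds shown alone.

Measured compounds:
Compound 1, `C[C@H](NCCSCCC(N)C(=O)O)C(=O)O`: 19.8%
Compound 2, `NC(CC[Se]CCCCC(=O)O)C(=O)O`: 100%
Compound 3, `CN(CCCSCCC(N)C(=O)O)CC(=O)O`: 79%

In an assay for inhibition of betaine--homocysteine S-methyltransferase 1 (Homo sapiens), tested at 20 uM (on this read-out higher numbers stand for more inhibition at the one concentration tested (going by the name of the read-out) and lower numbers for less inhibition), compound 1 gives 19.8%, the lowest of the three numbers. Its nearest neighbour is compound 3, which in this assay gives 79%, a difference that lies beyond the usual scatter. Compound 2, which in this assay gives 100%, lies furthest from compound 1, again beyond the scatter.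

Compound 4, `C[C@@H](NCCSCCC(N)C(=O)O)C(=O)O`, has not yet been measured. Its relation to compound 1 is this: the two compounds have the same atoms and bonds; at least one stereo element is drawn with a configuration in one of them and without one in the other: 1 of 2 stereo elements differ; a stereocentre at a saturated chain carbon is drawn S in compound 1 and R in compound 4. Going by the values given here, no pair of measured compounds differs in the same way, so there is no measured step to lean on. Such a change can leave the number unmoved or shift it either way. The expected step in this assay from compound 1 to compound 4 is a number 10.2 percentage points higher from compound 1 to compound 4 (beyond the scatter), a small rise that may still fall within the scatter. The estimated value for compound 4 in this assay is 30%, within a range from 5% to 65%.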

Compound 4, a percentage reported as inhibition, at one concentration (the size of the read-out at that concentration, not a potency): 15.5%
The estimate for compound 4 lay 14.5 percentage points above the measured number; the measured number falls inside the stated range.
By their numbers in this assay, from the lowest: compounds 4 and 1 (each within the scatter of the next); then compound 3; then compound 2.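

In this assay, drawing this saturated chain carbon R rather than S gives a number 4.3 percentage points lower from compound 1 to compound 4 (within the scatter), so the two compounds cannot be told apart at the one concentration tested. Going by these compounds alone, the earlier compounds differed from one another in more than one place and offered no single-place comparison; this pair is the first to isolate one change, and it shows that reversing this stereocentre alone does not lift the low number of compound 1. The comparison does carry a caution, which lies in how the two structures are drawn: the fact that one of compounds 1 and 4 is drawn with a defined configuration and the other without, at the place where they differ.

From the compounds shown here alone, it remains open whether the second stereo element, which does not differ between compound 1 and compound 4, affects the number. Also open, going by these compounds, is whether an ethyl group at the carbon that was flipped would change the number or make its configuration matter.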